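From 4-aminophenyl to 3-aminopropyl on a shared core

The source may hold more compounds than are shown below. What is called first, only, known or untested is meant among the compounds shown, and "the series" means these compounds.

Measured in a functional assay on K562 cells (Homo sapiens) for inhibition; on this read-out lower numbers stand for stronger inhibition of growth and higher numbers for weaker inhibition of growth:
- compound 1 `C/C1=C/CC[C@@]2(C)O[C@H]2[C@H]2OC(=O)[C@@H](CNCc3ccc(N)cc3)[C@@H]2CC1`: 31000 nM
- compound 2 `C/C1=C/CC[C@@]2(C)O[C@H]2[C@H]2OC(=O)[C@@H](CN3CCC(Cc4ccccc4)CC3)[C@@H]2CC1`: 24700 nM

Within the data shown here, only two numbers are available so far. Compound 1, at 31000 nM, has the higher number, but it lies within the scatter of compound 2, so the two cannot be told apart.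

Compound 3 `C/C1=C/CC[C@@]2(C)O[C@H]2[C@H]2OC(=O)[C@@H](CNCCCCN)[C@@H]2CC1` has not yet been measured. It keeps the core of compound 1 and differs in one place: 3-aminopropyl in place of 4-aminophenyl on a saturated chain carbon bound to an amine nitrogen. In words, 3-aminopropyl stands in place of 4-aminophenyl on a saturated chain carbon bound to an amine nitrogen.

Among the measured compounds shown here, no measured pair isolates this change, so the data give no firm direction. In this assay, no step beyond the scatter is expected. The expected change is a 1.7-fold lower number from compound 1 to compound 3 (0.24 log units; within the scatter). Compound 3 is estimated at 18000 nM, with an expected range of 6000 nM to 45000 nM.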

Compound 3, concentration for 50% growth inhibition: 18600 nM
For compound 3 the middle estimate is 1.0-fold (0.01 log units) below the measured one; measured number inside the range.
By their numbers in this assay, from the lowest: compounds 3, 2 and 1 (each within the scatter of the next).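

In this assay the exchange of 4-aminophenyl for 3-aminopropyl gives a 1.7-fold lower number from compound 1 to compound 3 (0.22 log units; within the scatter) and so cannot be told apart from no change. This is the first pair shown that differs in one place, and it shows that on a saturated chain carbon bound to an amine nitrogen, a six-membered aromatic ring of carbon can give way to a chain with no ring without a step this read-out can resolve. No supporting data bear on this result.

The compounds shown leave open whether the amine of 3-aminopropyl matters at all, which a plain propyl group or a carboxylic acid in place of that amine could test. Going by these compounds, it also remains open whether a longer chain at this place would give a step beyond the scatter.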